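Compound 2 to compound 3: replacing the methoxy

A few compounds are considered here, and "the series" means these few. Any claim that something is new, unique, unknown or untested is made for them only; others in the source may bear on it.

In a functional assay on SMOV2 cells (Homo sapiens) for antiproliferative activity, read by sulforhodamine B assay, with a stated time of 3 days (a higher number here means a weaker inhibitor of growth, a lower number a stronger inhibitor of growth), compound 1 (`CCc1cc(F)ccc1-c1nc(-c2ccc3[nH]c(=O)oc3c2)cs1`) gives 13 nM and compound 2 (`COc1cc(F)ccc1-c1nc(-c2ccc3[nH]c(=O)oc3c2)cs1`) gives 5700 nM, the higher of the two numbers. Compound 3 (`NCCOCc1cc(F)ccc1-c1nc(-c2ccc3[nH]c(=O)oc3c2)cs1`) is still unmeasured and changes compound 2 at one place: (2-aminoethoxy)methyl in place of methoxy on an aromatic carbon, ortho to a large group and meta to a fluoro group ((2-aminoethoxy)methyl in place of methoxy on an aromatic carbon). For the measured compounds named here, one measured step bears on this carbon: a 440-fold higher number from compound 1 to compound 2 (2.64 log units; beyond the scatter), which is large and beyond the scatter. That step shows the methoxy of compound 2 going with the high number, so leaving methoxy is expected to lower the number. Going by the values given here, no measured compound carries (2-aminoethoxy)methyl, so the size remains uncertain, and a return to the level of compound 1 is not assumed. The expected change in this assay is a 14-fold lower number from compound 2 to compound 3 (1.15 log units; beyond the scatter). For compound 3 the estimated value is 400 nM, with an expected range of 40 nM to 4000 nM.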

Compound 3, concentration for 50% growth inhibition: 3 nM
Compound 3: middle estimate off by 130-fold (2.12 log units), on the high side, outside the stated range (below it).
By their numbers in this assay, from the lowest: compound 3; then compound 1; then compound 2.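

In this assay the (2-aminoethoxy)methyl group gives a 1900-fold lower number from compound 2 to compound 3 (3.28 log units; beyond the scatter) and shows that this carbon, ortho to a large group and meta to a fluoro group, accepts a chain of 5 heavy atoms. Against the ethyl series member, the same chain gives a 4.3-fold lower number from compound 1 to compound 3 (0.64 log units; beyond the scatter) and so goes past the level of compound 1 rather than only regaining it, which means ethyl does not mark the best result at this carbon among the three compounds. Nothing available here accounts for either step.

The compounds shown do not separate the contribution of the amine from that of the ether oxygen or of the chain length. A hydroxyl or a carboxylic acid in place of the amine, a methoxymethyl group, or a longer chain would each bear on that question.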